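A few compounds are considered here, and "the series" means these few. Any claim that something is new, unique, unknown or untested is made for them only; others in the source may bear on it.

Measured so far:
compound 1, `COc1cc([C@@H]2c3cc(OC)c(O)cc3C(=O)[C@@H](C)[C@H]2C)ccc1O` — compound 1 gives 59.7% in a functional assay on PBMC cells (Homo sapiens) for inhibition, read by scintillation counting and thymidine incorporation, with a stated time of 3 days, tested at 100 uM; a higher number here means more inhibition at the concentration tested (going by the name of the read-out), a lower number less inhibition
compound 2, `COc1cc2c(cc1O)C(=O)[C@@H](C)[C@@H](C)[C@@H]2c1ccc(OC)c(OC)c1` — compound 2 gives 54.1% in this assay

Compound 2 stands lowest of these two numbers, with compound 1 nearest, and the step of a number 5.6 percentage points lower from compound 1 to compound 2 (within the scatter) lies within the scatter. Compound 3, `COc1cc2c(cc1O)C(=O)[C@H](C)[C@@H](C)[C@@H]2c1ccc(OC)c(OC)c1`, differs from compound 2 only in configuration: the two compounds have the same atoms and bonds and differ only in configuration as drawn: 1 of 3 stereo elements differ; a stereocentre at a saturated ring carbon is drawn S in compound 2 and R in compound 3. Among the compounds with values here, the one measured step, a number 5.6 percentage points lower from compound 1 to compound 2 (within the scatter), concerns a methyl on an oxygen, not a stereocentre, so no measured step bears on this change. No step beyond the scatter is therefore expected in this assay. The estimated step of a number 4.1 percentage points lower from compound 2 to compound 3 (within the scatter) is small. For compound 3 the estimate is 50%, ranging from 25% to 70%.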

Compound 3, a percentage reported as inhibition, at one concentration (the size of the read-out at that concentration, not a potency): 34.1%
The estimate for compound 3 lay 15.9 percentage points above the measured number; measured number inside the range.
By their numbers in this assay, from the lowest: compound 3; then compounds 2 and 1 (each within the scatter of the next).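

In this assay, within the data shown here, switching a stereocentre at a saturated ring carbon from S to R gives a number 20 percentage points lower from compound 2 to compound 3 (beyond the scatter), the first step here to exceed the scatter. Three-dimensional arrangement at this one carbon can therefore change the read-out, and the shift can be assigned to that carbon alone because nothing else changes: the fact that compounds 2 and 3 differ only in the configuration as drawn

Still open, as far as these compounds go, is whether the same switch would have a similar effect in compound 1, and what the other stereo elements contribute. The compounds shown also cannot tell how an amine or a carboxylic acid on the shared core would behave.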